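Phenyl on the alkyne of a nucleoside carboxamide

The source may report more compounds than this note shows. Statements on the series, on what has been measured and on what is new or still open speak of the compounds shown alone.

Compound 1 `NC(=O)c1ncn(C2O[C@H](CO)[C@@H](O)[C@H]2O)c1C#CCO`: 0.7 ug/mL
Compound 2 `NC(=O)c1ncn(C2O[C@H](CO)[C@@H](O)[C@H]2O)c1C#CCCO`: 1.28 ug/mL
Compound 3 `CCCCC#Cc1c(C(N)=O)ncn1C1O[C@H](CO)[C@@H](O)[C@H]1O`: 2.29 ug/mL

All values come from a functional assay on L1210 cells (Mus musculus) for inhibition; on this read-out lower numbers stand for stronger inhibition and higher numbers for weaker inhibition. Compound 3 has the highest number of the three; its gap to compound 2 is within the scatter, while a 3.3-fold higher number from compound 1 to compound 3 (0.51 log units; beyond the scatter) is beyond it. Compound 4 `NC(=O)c1ncn(C2O[C@H](CO)[C@@H](O)[C@H]2O)c1C#Cc1ccccc1` differs from compound 3 by phenyl in place of butyl on a triple-bonded carbon. Going by the values given here, none of the measured steps swaps in an aromatic ring; they only exchange a hydroxy for a hydroxymethyl, a 1.8-fold higher number from compound 1 to compound 2 (0.26 log units; within the scatter), or for a hydrocarbon chain, a 1.8-fold higher number from compound 2 to compound 3 (0.25 log units; within the scatter). Those steps give no direct guide, so compound 4 is expected to stay close to compound 3, with a small step in this assay of a 1.3-fold higher number from compound 3 to compound 4 (0.12 log units; within the scatter), estimated at 3 ug/mL within 0.8 ug/mL to 12 ug/mL.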

Compound 4, half-maximal inhibitory concentration: 20.6 ug/mL
Estimate against measurement, compound 4: 6.9-fold (0.84 log units) below; the whole stated range lies below it.
By their numbers in this assay, from the lowest: compounds 1, 2 and 3 (each within the scatter of the next, the first and the last beyond it); then compound 4.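

On the triple-bonded carbon, phenyl in place of butyl gives a 9.0-fold higher number from compound 3 to compound 4 (0.95 log units; beyond the scatter) and so sets this ring further from the butyl chain than the widest step among the open chains, a 3.3-fold higher number from compound 1 to compound 3 (0.51 log units; beyond the scatter) within that series. Against the chains that carry a hydroxy group, the steps are larger still: a 16-fold higher number from compound 2 to compound 4 (1.21 log units; beyond the scatter) and a 29-fold higher number from compound 1 to compound 4 (1.47 log units; beyond the scatter) for the same ring. No measurement shown here explains this loss of inhibition. On these data alone, whether a cyclohexyl ring, a benzyl group or a phenyl ring carrying an amine would behave like phenyl stays open.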